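The source may report more compounds than this note shows. Statements on the series, on what has been measured and on what is new or still open speak of the compounds shown alone.

Working notes on the series. Compound 3 `Cc1cc(-c2cccs2)cn2c(CSCCc3ccccc3)cnc12` in an ADME assay on HEL cells (Homo sapiens) for cytotoxicity, with a stated time of 3 days (on this read-out lower numbers stand for higher toxicity in this test and higher numbers for lower toxicity in this test), gives 32 ug/mL. Compound 1 `Cc1cc(-c2ccccc2)cn2c(CSCCc3ccccc3)cnc12` in this assay gives 31 ug/mL, and the two numbers sit within the scatter of one another, as the step of a 1.0-fold higher number from compound 1 to compound 3 (0.01 log units; within the scatter) shows. Compound 2 `Cc1cc(-c2ccsc2)cn2c(CSCCc3ccccc3)cnc12` gives > 50 ug/mL, which is a limit of this assay rather than a number (the limit of > 50 ug/mL in this assay, at which 1 of the 3 values shown sits). The steps of an at least 1.6-fold higher number from compound 1 to compound 2 (0.20 log units; that floor lies within the scatter) and an at least 1.5-fold lower number from compound 2 to compound 3 (0.19 log units; that floor lies within the scatter) each carry a floor that lies within the scatter.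

Compound 4 `Cc1cc(-c2ccccc2O)cn2c(CSCCc3ccccc3)cnc12` is not yet measured. It differs from compound 3 by 2-hydroxyphenyl in place of thiophen-2-yl on an aromatic carbon. The measured steps that swap one aromatic ring for another on that aromatic carbon, a 1.0-fold higher number from compound 1 to compound 3 (0.01 log units; within the scatter) and an at least 1.6-fold higher number from compound 1 to compound 2 (0.20 log units; that floor lies within the scatter), stayed within the scatter. Within the data shown here, no measured step brings in a hydroxyl group, so the expectation rests on the ring swaps alone: no step beyond the scatter in this assay. For compound 4 the estimated value in this assay is 35 ug/mL, with a range from 17 ug/mL to 70 ug/mL. The step this estimate implies is a 1.1-fold higher number from compound 3 to compound 4 (0.04 log units; within the scatter).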

Compound 4, half-maximal cytotoxic concentration: > 50 ug/mL
Compound 4 gave a limit, no number; the forecaster's own chance of this, stated with the estimate: 25%; at least 1.4-fold (0.15 log units) between middle value and limit.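

Compound 4, with 2-hydroxyphenyl on this aromatic carbon, gives > 50 ug/mL in this assay, which is a limit and not a number: the limit of > 50 ug/mL in this assay, at which 2 of the 4 values shown sit. This is the first hydroxyl group and the first hydrogen-bond donor shown at this position, and the number does not fall with either swap, though both floors lie within the scatter (an at least 1.5-fold higher number from compound 3 to compound 4 (0.19 log units; that floor lies within the scatter); an at least 1.6-fold higher number from compound 1 to compound 4 (0.20 log units; that floor lies within the scatter)). The step between compound 2 and compound 4 joins two limits and cannot be read.

Going by these compounds, how far compound 2 and compound 4 lie beyond the limit of this assay stays open, so any order between them is unknown. Also open, on these data alone, is whether a methoxy group or an amine on the same phenyl ring, or a carboxylic acid in place of the hydroxyl group, would keep the read-out at that limit.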